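The source may report more compounds than this note shows. Statements on the series, on what has been measured and on what is new or still open speak of the compounds shown alone.

Measured so far:
compound 1, `COc1cc(-c2cc(/C=C/C(=O)c3ccc(N)cc3)[nH]n2)cc(OC)c1OC`: 92%
compound 2, `COc1ccc(-c2cc(/C=C/C(=O)c3ccc(OC)c(OC)c3)[nH]n2)cc1`: 95%

In a functional assay on COLO 205 cells (Homo sapiens) for cytotoxicity, read by sulforhodamine B assay, with a stated time of 48 h, tested at 1 uM (on this read-out lower numbers stand for a stronger effect and higher numbers for a weaker effect at the one concentration tested), compound 1 gives 92% and compound 2 gives 95%; the two numbers lie within the scatter of each other, so neither can be called the stronger. Compound 3, `COc1cc(-c2cc(/C=C/C(=O)c3ccc(Cl)c(Cl)c3)[nH]n2)cc(OC)c1OC`, has not been measured. It differs from compound 1 in one place: 3,4-dichlorophenyl in place of 4-aminophenyl on a carbonyl carbon. Going by the values given here, no step between measured compounds shows what this change does, so in this assay the expected step from compound 1 to compound 3 is a number 7 percentage points lower from compound 1 to compound 3 (within the scatter), at most a small one and not beyond the scatter. Compound 3 is therefore expected to give 85%, within 60% to 100%.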

Compound 3, a percentage reported as activity, at one concentration (the size of the read-out at that concentration, not a potency): 54%
Compound 3: middle estimate off by 31 percentage points, on the high side, outside the stated range (below it).
By their numbers in this assay, from the lowest: compound 3; then compounds 1 and 2 (each within the scatter of the next).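

In this assay, putting 3,4-dichlorophenyl in place of 4-aminophenyl on a carbonyl carbon gives a number 38 percentage points lower from compound 1 to compound 3 (beyond the scatter) and so shows that the group held at this position can matter greatly for the read-out. The earlier pair could not show this, since those two compounds differ in more than one place. Nothing measured here explains the step.

The compounds shown leave open whether 4-chlorophenyl or plain phenyl at this position would match 3,4-dichlorophenyl. They also leave open whether the loss of 4-aminophenyl or the arrival of the chlorines accounts for the step.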